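The source may report more compounds than this note shows. Statements on the series, on what has been measured and on what is new or still open speak of the compounds shown alone.

Of the compounds shown here, two have been tested so far. Compound 1 `Cc1ccc(NCC2CCC/C(=C\c3ccccc3)C2=O)cc1` gives 56.4% in a functional assay on the whole organism (Ear, strain Kunming) for inhibition, with Mus musculus as the target, with stated times of 1 h and 30 min, at a dose of 200 mg/kg by the oral route; on this read-out lower numbers stand for less inhibition and higher numbers for more inhibition at the one dose given (going by the name of the read-out). Compound 2 `CN(CC1CCC/C(=C\c2ccccc2)C1=O)c1ccccc1` gives 49.7% in this assay. These two numbers lie within the usual scatter of repeated measurements of one another, so neither compound can be said to stand apart from the other on this read-out.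

Compound 3 `Cc1ccc(N(C)CC2CCC/C(=C\c3ccccc3)C2=O)cc1` has not yet been measured. It differs from compound 2 in one place: methyl in place of hydrogen on an aromatic carbon. Seen one bond further out, the change reads phenyl to 4-methylphenyl.

For the measured compounds named here, no pair of measured compounds differs in only this one place, so nothing is known here about what such a change does to inhibition. The expectation for compound 3 is therefore a step from compound 2 of about a number 2.3 percentage points higher from compound 2 to compound 3 (within the scatter), that is, none beyond the scatter. Compound 3 is estimated to give 52%, within a range from 35% to 70%.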

Compound 3, a percentage reported as inhibition, in the whole organism at one dose (the size of the read-out at that dose, not a potency): 18.3%
Beside the measured number, compound 3's estimate is 33.7 percentage points above it, and the stated range ends above it.
By their numbers in this assay, from the lowest: compound 3; then compounds 2 and 1 (each within the scatter of the next).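

In this assay the change from phenyl to 4-methylphenyl, a methyl on an aromatic carbon para to a large group, gives a number 31.4 percentage points lower from compound 2 to compound 3 (beyond the scatter) and so shows that this small addition can matter a great deal when the nitrogen carries a methyl. Methyl in place of hydrogen on the nitrogen, with the 4-methylphenyl kept, gives a number 38.1 percentage points lower from compound 1 to compound 3 (beyond the scatter) and shows that the nitrogen is just as sensitive to one added carbon when the ring carries its methyl. Compound 3 is the only compound shown with both methyl groups, and nothing measured here explains why its number is so low.

Open, as far as these compounds go, is whether the loss is specific to methyl, or whether a chlorine atom or a methoxy group at the same ring place would do the same. Also open, from the compounds shown here alone, is whether an ethyl group on the nitrogen would follow the methyl.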